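Replacing a Dimethoxybenzyl with a Fluorobenzyl Group

A few compounds are considered here, and "the series" means these few. Any claim that something is new, unique, unknown or untested is made for them only; others in the source may bear on it.

Measured compounds and their values:
Compound 1 `COc1ccc(CNc2nc3cc(N)cc(N)c3nc2-c2ccccc2)cc1OC` — 32400 nM
Compound 2 `COc1cc(CNc2nc3cc(N)cc(N)c3nc2-c2ccccc2)cc(OC)c1OC` — 11200 nM
Compound 3 `CCOC(=O)[C@H](CCC(=O)O)NC(=O)c1ccc(Oc2nc3cc(N)cc(N)c3nc2-c2ccccc2)cc1` — < 100000 nM

In a functional assay on BT-549 cells (Homo sapiens) for inhibition, read by sulforhodamine B assay, with a stated time of 48 h (a higher number here means a weaker inhibitor of growth, a lower number a stronger inhibitor of growth), compound 1 gives 32400 nM, the highest of the two numbers that were read as numbers. A methoxy in place of hydrogen on an aromatic carbon distinguishes compound 1 from compound 2, and compound 2 gives 11200 nM; the step of a 2.9-fold lower number from compound 1 to compound 2 (0.46 log units; beyond the scatter) lies beyond the scatter. Compound 3 gives only a limit, < 100000 nM, and no number; this is the limit of < 100000 nM in this assay, at which 1 of the 3 values shown sits.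

Compound 4 `Nc1cc(N)c2nc(-c3ccccc3)c(NCc3ccc(F)cc3)nc2c1` has not yet been measured. It differs from compound 1 in one place: 4-fluorophenyl in place of 3,4-dimethoxyphenyl on a saturated chain carbon bound to a nitrogen on an aromatic ring. Among the measured compounds shown here, no measured step bears directly on this change. For the measured compounds named here, the single measured step, from compound 1 to compound 2, concerned an added methoxy on the same benzyl ring and was modest; it says nothing about the loss of both methoxy groups and the entry of fluorine. With nothing pointing in either direction, compound 1 is taken as the anchor and compound 4 is expected to sit near it, with a step of a 1.1-fold lower number from compound 1 to compound 4 (0.03 log units; within the scatter) that would fall within the scatter. Compound 4 is therefore estimated at 30000 nM, with a range from 10000 nM to 90000 nM.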

Compound 4, concentration for total growth inhibition: 3240 nM
Beside the measured number, compound 4's estimate is 9.3-fold (0.97 log units) above it; measured number outside the range, below it.
By their numbers in this assay, from the lowest: compound 4; then compound 2; then compound 1.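

In this assay, among the compounds shown here, the earlier compounds showed only a modest change on this benzyl ring when a methoxy was added, a 2.9-fold lower number from compound 1 to compound 2 (0.46 log units; beyond the scatter), whereas the exchange of 3,4-dimethoxyphenyl for 4-fluorophenyl on the same saturated chain carbon gives a larger step, a 10-fold lower number from compound 1 to compound 4 (1.00 log units; beyond the scatter). The methoxy groups are therefore not required for growth inhibition at this position, and the number does not follow the count of methoxy groups in one direction: adding one lowers it from compound 1 to compound 2, yet compound 4, which carries none, also has a lower number than compound 1. Nothing shown here gives a reason for this step.

As far as these compounds go, the step removes both methoxy groups and brings in fluorine at once, so the share of each remains open, and an unsubstituted phenyl or a 4-chlorophenyl at this place would separate them. Also open, from the compounds shown here alone, is whether the number would fall further or rise with an amine or a carboxylic acid on this ring, or with a longer chain between the ring and the nitrogen.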